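Benzimidazole hydroxamates: methylating the ring nitrogen of compound 1

The compounds below may be only part of what the source reports. "The series", "measured", "known", "first", "only" and "open" are said of these compounds alone.

Among the compounds with values here, compound 1 `O=C(CCCCCCc1nc2ccccc2[nH]1)NO` gives 2700 nM in a functional assay on SK-OV-3 cells (Homo sapiens) for cytotoxicity (a lower number here means a stronger inhibitor, a higher number a weaker inhibitor), the second highest of the three numbers measured so far. Compound 3 `O=C(CCCCCCc1nc2ccc(-c3cncnc3)cc2[nH]1)NO` gives 2600 nM; the step is a 1.0-fold lower number from compound 1 to compound 3 (0.02 log units; within the scatter). Compound 2 `O=C(CCCCCc1nc2ccccc2[nH]1)NO` gives 11000 nM; the step is a 4.1-fold higher number from compound 1 to compound 2 (0.61 log units; beyond the scatter). Compound 4 `Cn1c(CCCCCCC(=O)NO)nc2ccccc21` differs from compound 1 by methyl in place of hydrogen on an aromatic nitrogen. Within the data shown here, neither measured step touches the aromatic nitrogen: the step to compound 2 shortens the chain, the step to compound 3 adds pyrimidin-5-yl, so no measured step bears directly on this change. Without such guidance, the number for compound 4 is expected to stay near that of compound 1, with a wide range, giving an expected step of a 1.3-fold higher number from compound 1 to compound 4 (0.11 log units; within the scatter). For compound 4 the estimate in this assay is 3500 nM, from 1200 nM to 12000 nM.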

Compound 4, half-maximal inhibitory concentration: 3000 nM
The estimate for compound 4 lay 1.2-fold (0.07 log units) above the measured number; low and high end bracket the measured number.
By their numbers in this assay, from the lowest: compounds 3, 1 and 4 (each within the scatter of the next); then compound 2.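

In this assay the step with methyl in place of hydrogen on the aromatic nitrogen, a 1.1-fold higher number from compound 1 to compound 4 (0.05 log units; within the scatter), stays within the scatter. Within the data shown here, this gives the first reading at this position: the hydrogen on this nitrogen is not required to keep the number in the range of compound 1. Nothing available explains this result.

Open, going by these compounds, is whether benzyl or an aminoethyl chain on this nitrogen would be tolerated like methyl. Also open, on these data alone, is whether methyl here would behave the same on the pyrimidin-5-yl compound 3 or the shorter-chain compound 2.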